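The compounds below may be only part of what the source reports. "The series", "measured", "known", "first", "only" and "open" are said of these compounds alone.

Measured compounds in the series:

compound 1, `CCCCc1ccc2[nH]c(-c3ccc(CC)cc3)c(C=O)c2c1`: 27 nM
compound 2, `CCCCc1ccc2[nH]c(-c3ccc(OC)cc3)c(/C=N/O)c2c1`: 40 nM

Two compounds carry a number in a functional assay on MDA-MB-231 cells (Homo sapiens) for antiproliferative activity, with a stated time of 4 days (on this read-out lower numbers stand for stronger inhibition and higher numbers for weaker inhibition), and both sit close together. Among the compounds with values here, compound 2 gives 40 nM there, and compound 1 gives 27 nM; the gap between them lies within the scatter of repeated runs, so the two cannot be told apart on these data, and no step between measured compounds is available to lean on.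

Compound 3, `CCCCc1ccc2[nH]c(-c3ccc(OC)cc3)c(/C=N/NC(=O)c3ccccn3)c2c1`, remains to be measured. It differs from compound 2 in one place: ((pyridin-2-yl)carbonyl)amino in place of hydroxy on a double-bonded nitrogen. Within the data shown here, the change is large in what is counted, yet the data hold no example of a comparable replacement, so the direction cannot be read off from any measured pair. The working expectation is a modest step in this assay, probably toward a somewhat higher number, but not one that stands clearly outside the scatter.

On that basis compound 3 is estimated at 60 nM in this assay, with a range of 15 nM to 250 nM, which corresponds to an expected step of a 1.5-fold higher number from compound 2 to compound 3 (0.18 log units; within the scatter).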

Compound 3, half-maximal inhibitory concentration: 34 nM
The estimate for compound 3 lay 1.8-fold (0.25 log units) above the measured number; measured number inside the range.
By their numbers in this assay, from the lowest: compounds 1, 3 and 2 (each within the scatter of the next).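

In this assay, within the data shown here, ((pyridin-2-yl)carbonyl)amino in place of hydroxy on the double-bonded nitrogen gives a 1.2-fold lower number from compound 2 to compound 3 (0.07 log units; within the scatter) and this is the first measured pair that differs in one place. The replacement brings in a far larger group with a six-membered aromatic ring, yet the step cannot be told apart from the scatter of repeated runs, so this single pair shows that the position can carry such a group with no readable change in this antiproliferative read-out. Nothing at hand bears on what lies behind this result.

Still open, on these data alone, is whether the same holds for other groups on that nitrogen, such as a plain amine, a methoxy group or a benzoylamino group, the last of which would show whether the ring nitrogen of the pyridine matters. Compound 1 differs from compound 2 in more than one place, so neither its ethyl group nor its carbonyl can be weighed alone.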